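A few compounds are considered here, and "the series" means these few. Any claim that something is new, unique, unknown or untested is made for them only; others in the source may bear on it.

Within the data shown here, in an ADME assay on MT4 cells (Homo sapiens) for cytotoxicity, read by MTT assay, with a stated time of 4 days (on this read-out higher numbers stand for lower toxicity in this test and lower numbers for higher toxicity in this test), none of the three compounds measured so far returns a number. Compound 1 `O=c1cc(Cc2c(F)cccc2N2CCCC2)nc(N2CCCC2)[nH]1` stands at > 73000 nM, which is a limit of the assay. Compound 2 `O=c1cc(Cc2c(F)cccc2F)nc(-n2cccc2)[nH]1` stands at > 87000 nM, which is also a limit. Compound 3 `Cc1c(Cc2c(F)cccc2F)nc(N(C)C2CCCCC2)[nH]c1=O` stands at > 72000 nM, again a limit, so its place among the three cannot be ranked.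

Compound 4 `Cc1c(Cc2c(F)cccc2F)nc(N2CCCC(C)C2)[nH]c1=O` keeps the rest of compound 3 and carries one change: 3-methylpiperidin-1-yl in place of cyclohexyl(methyl)amino on an aromatic carbon, between two ring nitrogen atoms (3-methylpiperidin-1-yl in place of cyclohexyl(methyl)amino on an aromatic carbon). Among the measured compounds shown here, no measured pair isolates this change, so the expectation rests on the limit of compound 3 and on the fact that all three compounds in this assay gave only limits. No step beyond the usual scatter is expected, in either direction. The expected step, a step that the limit leaves unreadable from compound 3 to compound 4, is therefore small. Compound 4 is estimated at 75000 nM, with an expected range from 30000 nM to 120000 nM, and it may well be reported only as a limit.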

Compound 4, half-maximal cytotoxic concentration: > 75000 nM
Compound 4: no number, only a limit (the forecaster's own chance of this, stated with the estimate: 75%); the middle value lies on the limit itself.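

In this assay compound 4 gives > 75000 nM, a limit of the assay and not a number. Among these compounds, with compound 3 also only a limit, no step between compound 3 and compound 4 can be read. The compounds shown leave open at what concentration any of them becomes cytotoxic.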